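The source may report more compounds than this note shows. Statements on the series, on what has been measured and on what is new or still open speak of the compounds shown alone.

Measured so far, all in a functional assay on cells (Cancer cell lines, Homo sapiens) for inhibition; on this read-out higher numbers stand for weaker inhibition of growth and lower numbers for stronger inhibition of growth:
- compound 1 `Cc1cc(-c2nc3sc(C)cn3c2/C=N/NC(=N)N)c(C)s1`: 4790 nM
- compound 2 `Cc1cn2c(/C=N/NC(=N)N)c(-c3ccsc3)nc2s1`: 7590 nM
- compound 3 `N=C(N)N/N=C/c1c(-c2cc(Cl)sc2Cl)nc2n1CCS2`: 8130 nM

Compound 3 at 8130 nM lies within the scatter of both compound 1 and compound 2, so the three numbers form a single group.

The next compound is compound 4 `Cc1cc(-c2nc3n(c2/C=N/NC(=N)N)CCS3)c(C)s1`, not yet measured. It carries 2,5-dimethylthiophen-3-yl in place of the 2,5-dichlorothiophen-3-yl of compound 3, on an aromatic carbon of a five-membered aromatic ring with 2 nitrogen: 2,5-dimethylthiophen-3-yl in place of 2,5-dichlorothiophen-3-yl on an aromatic carbon.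

Going by the values given here, no measured step makes this exchange directly. The nearest evidence is a change to the same thiophene group, a 1.6-fold higher number from compound 1 to compound 2 (0.20 log units; within the scatter), with thiophen-3-yl in place of 2,5-dimethylthiophen-3-yl. Among the compounds with values here, that step is small, though it is only a single step and was measured on a different core. Compound 1 already carries the entering 2,5-dimethylthiophen-3-yl and gives 4790 nM, again on that other core.

On this basis, no shift beyond the scatter is expected in this assay. The estimated step is a 1.4-fold lower number from compound 3 to compound 4 (0.13 log units; within the scatter). Compound 4 is expected at 6000 nM, with an estimated range of 3000 nM to 12000 nM.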

Compound 4, concentration for 50% growth inhibition: 15500 nM
For compound 4 the middle estimate is 2.6-fold (0.41 log units) below the measured one; the whole stated range lies below it.
By their numbers in this assay, from the lowest: compounds 1, 2, 3 and 4 (each within the scatter of the next, the first and the last beyond it).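

Going by these compounds alone, on the core shared by compound 3 and compound 4, in this assay, exchanging 2,5-dichlorothiophen-3-yl for 2,5-dimethylthiophen-3-yl gives a 1.9-fold higher number from compound 3 to compound 4 (0.28 log units; within the scatter) and so gives the first direct reading of this change at this position, on an aromatic carbon next to the ring nitrogen; the two chlorine atoms and the two methyl groups are not told apart here beyond the scatter. Within the data shown here, with 2,5-dimethylthiophen-3-yl held constant, compound 1 gives 4790 nM on its own core and compound 4 gives 15500 nM on the other, and these two values lie beyond the scatter of each other, which the earlier compounds could not show for this group. Nothing available on these compounds accounts for either reading.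

As far as these compounds go, whether an amine or a carboxylic acid on this aromatic carbon, in place of the substituted thiophene, would move the number beyond the scatter remains open. Also open, from the compounds shown here alone, is what the plain thiophen-3-yl gives on the core of compound 3 and compound 4, and whether the small thiophene steps seen so far hold on both cores.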